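Bromo for Chloro at the Limit of the Assay

The compounds below may be only part of what the source reports. "The series", "measured", "known", "first", "only" and "open" are said of these compounds alone.

Compound 1 `CC1(C)CNC(=O)c2cc(-c3ccc([N+](=O)[O-])cc3)n(-c3ccc(Br)cc3)c2C1` gives > 100000 nM in a functional assay on K562 cells (Homo sapiens) for cytotoxicity, read by sulforhodamine B assay, with a stated time of 48 h (a lower number here means a stronger inhibitor, a higher number a weaker inhibitor), which is a limit of the assay and not a number. Compound 2 `CC1(C)CNC(=O)c2cc3n(c2C1)CCc1ccccc1-3` gives > 100000 nM, and this too is a limit. Compound 3 `CC1(C)CNC(=O)c2cc3n(c2C1)CCc1cc(Cl)ccc1-3` gives > 100000 nM, again a limit. So compound 3 cannot be ranked against the other two, and the whole set sits at one end of the scale: the limit of > 100000 nM in this assay, at which 3 of the 3 values shown sit.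

Compound 4 `CC1(C)CNC(=O)c2cc3n(c2C1)CCc1cc(Br)ccc1-3` has not yet been measured. It differs from compound 3 by a single exchange, bromo in place of chloro on an aromatic carbon.

The closest measured change is a step that the two limits leave unreadable from compound 2 to compound 3, which put chloro in place of hydrogen on an aromatic carbon. Both ends of that step are limits, so it has no readable size and shows no direction. The expectation therefore rests mainly on compound 3, whose > 100000 nM is a limit. The step expected in this assay is a number no higher from compound 3 to compound 4 (the limit leaves the size open), with no change beyond the scatter anticipated in either direction. Another reading at the limit is the most likely result. The estimate for compound 4 is 100000 nM, with an expected range from 50000 nM to 200000 nM.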

Compound 4, half-maximal inhibitory concentration: 36100 nM
Estimate against measurement, compound 4: 2.8-fold (0.44 log units) above; the measured number lies below the stated range.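

In this assay, this aromatic carbon proves to be a place where one exchange can bring a readable value into the series: compound 4 gives 36100 nM, the first number shown that is not a limit. Putting bromo in place of chloro gives an at least 2.7-fold lower number from compound 3 to compound 4 (0.44 log units; beyond the scatter), and putting bromo in place of hydrogen gives an at least 2.7-fold lower number from compound 2 to compound 4 (0.44 log units; beyond the scatter), so the choice of halogen matters at this position, something that the chloro compound alone could not reveal. These sizes are only minimums and the step that put chloro in place of hydrogen cannot be read, because the other compounds stand at a limit of the assay: the limit of > 100000 nM in this assay, at which 3 of the 4 values shown sit.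

The compounds shown do not tell whether iodo at the same carbon would lower the number further, or whether fluoro, methyl or methoxy there would also give a readable value. Nor do they show whether bromo on another carbon of this six-membered aromatic ring would give a similar step, or whether the step from chloro to bromo would hold in cells other than those used in this assay.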